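The compounds below may be only part of what the source reports. "The series", "measured", "known", "first", "only" and "open" are said of these compounds alone.

Measured so far in a functional assay on CCRF-CEM cells (Homo sapiens), read by MTT assay, with a stated time of 72 h; a lower number here means a stronger inhibitor, a higher number a weaker inhibitor:
- compound 1 `Nc1nc(N)c2c(-c3cc4ccccc4o3)cn([C@@H]3O[C@H](CO)[C@@H](O)[C@H]3O)c2n1`: > 20000 nM
- compound 2 `Cc1nc(N)c2c(-c3cc4ccccc4o3)cn([C@@H]3O[C@H](CO)[C@@H](O)[C@H]3O)c2n1`: > 20000 nM
- compound 3 `C#Cc1cn([C@@H]2O[C@H](CO)[C@@H](O)[C@H]2O)c2ncnc(C)c12`: 5600 nM

Compound 2 gives only a limit in this assay, > 20000 nM, so its position on the numbers is not fixed. Compound 1 likewise sits at a limit, > 20000 nM; the one step shown, a step that the two limits leave unreadable from compound 1 to compound 2, is therefore unreadable, as both values rest on (the limit of > 20000 nM in this assay, at which 2 of the 3 values shown sit).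

Compound 4 `C#Cc1cn([C@@H]2O[C@H](CO)[C@@H](O)[C@H]2O)c2nc(C)nc(N)c12` differs from compound 2 by ethynyl in place of 1-benzofuran-2-yl on an aromatic carbon. Among the compounds with values here, no measured step covers this exchange. Compound 3 carries the ethynyl group on a core differing from that of compound 4. In this assay, within the data shown here, compound 3 gives 5600 nM, the only measured number in the set. Compound 4 is expected near 8000 nM, within 1500 nM to 30000 nM. The expected step is an at least 2.5-fold lower number from compound 2 to compound 4 (0.39 log units; beyond the scatter).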

Compound 4, half-maximal inhibitory concentration: > 20000 nM
Compound 4: no number, only a limit; the forecaster's own chance of this, stated with the estimate: 35%; at least 2.5-fold (0.39 log units) between middle value and limit.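

Compound 4 gives > 20000 nM, a limit and not a number, and compound 2 also sits at a limit, so no step between them can be read: the limit of > 20000 nM in this assay, at which 3 of the 4 values shown sit.

On these data alone, whether ethynyl or 1-benzofuran-2-yl gives the lower number on this shared core remains open.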